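Changing the ring on a sulfur

The source may report more compounds than this note shows. Statements on the series, on what has been measured and on what is new or still open speak of the compounds shown alone.

Compound 1 `Cc1cc(C)cc(SCc2ccc(/C=C/C(=O)Nc3ccccc3N)cc2)c1`: 7.98%
Compound 2 `Nc1ccccc1NC(=O)/C=C/c1ccc(CSc2cccc(F)c2)cc1`: 7.95%
Compound 3 `COc1ccc(SCc2ccc(C(=O)Nc3ccccc3N)cc2)cc1`: 73.3%

In a functional assay on HCT-116 cells (Homo sapiens) for inhibition, read by CCK-8 assay, with a stated time of 72 h, tested at 2 uM (a lower number here means less inhibition of growth, a higher number more inhibition of growth at the concentration tested), compound 2 gives 7.95%, level with compound 1 within the scatter, while compound 3 stands far higher at 73.3%. Compound 4 `Nc1ccccc1NC(=O)/C=C/c1ccc(CSc2ccc(C(F)(F)F)cn2)cc1` differs from compound 2 in one place, on a sulfur: 5-(trifluoromethyl)pyridin-2-yl in place of 3-fluorophenyl on a sulfur. It carries 5-(trifluoromethyl)pyridin-2-yl in place of 3-fluorophenyl. Among the measured compounds shown here, only one measured step touches this place, a number 0 percentage points lower from compound 1 to compound 2 (within the scatter), and it stays within the scatter. That step swaps one carbon-only ring for another, so it is thin evidence for a ring with a hetero atom. Still, nothing measured points to a large move, and the expected change is slight: an estimated a number 2.1 percentage points higher from compound 2 to compound 4 (within the scatter), within the scatter. Compound 4 is estimated at 10%, with an expected range from 2% to 30%.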

Compound 4, percent growth inhibition at one concentration: 4.42%
Compound 4: the middle estimate sits 5.6 percentage points above what was measured; low and high end bracket the measured number.
By their numbers in this assay, from the lowest: compounds 4, 2 and 1 (each within the scatter of the next); then compound 3.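

Placing a ring with a hetero atom on the sulfur leaves the number unmoved: 5-(trifluoromethyl)pyridin-2-yl in place of 3-fluorophenyl gives a number 3.5 percentage points lower from compound 2 to compound 4 (within the scatter), and in place of 3,5-dimethylphenyl it gives a number 3.6 percentage points lower from compound 1 to compound 4 (within the scatter). In this assay compounds 1, 2 and 4 therefore stand level, so the flat result now covers carbon-only rings and this pyridine ring alike. No measurement shown here explains this flat result. As far as these compounds go, whether a ring carrying an amine or a carboxylic acid on this sulfur would lift the number remains open.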